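The source may report more compounds than this note shows. Statements on the series, on what has been measured and on what is new or still open speak of the compounds shown alone.

Going by the values given here, in a functional assay on MCF7 cells (Homo sapiens) for cytotoxicity, read by MTT assay, with a stated time of 72 h (on this read-out higher numbers stand for weaker inhibition and lower numbers for stronger inhibition), compound 1 `COC(=O)c1sc2ccccc2c1Nc1cc(OC)c(OC)c(OC)c1` gives 795 nM, the lower of the two numbers so far, while compound 2 `COC(=O)c1sc2cccc(C)c2c1Nc1cc(OC)c(OC)c(OC)c1` gives 8190 nM. Compound 3 `COC(=O)c1sc2ccc(C)cc2c1Nc1cc(OC)c(OC)c(OC)c1` keeps the core of compound 1 and differs from it by methyl in place of hydrogen on an aromatic carbon. Among the compounds with values here, the one measured step that bears on this is the same kind of swap at another aromatic carbon, a 10-fold higher number from compound 1 to compound 2 (1.01 log units; beyond the scatter), which is large and beyond the scatter. One example cannot show how a new place will behave, so a smaller rise in the same direction is expected. The estimated step is a 2.5-fold higher number from compound 1 to compound 3 (0.40 log units; beyond the scatter). For compound 3 the expected value is 2000 nM, with an estimated range from 400 nM to 9000 nM.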

Compound 3, half-maximal inhibitory concentration: 540 nM
For compound 3 the middle estimate is 3.7-fold (0.57 log units) above the measured one, within the range that was stated.
By their numbers in this assay, from the lowest: compounds 3 and 1 (each within the scatter of the next); then compound 2.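

With methyl on this aromatic carbon, meta to a fused ring and para to a fused ring, this assay shows a 1.5-fold lower number from compound 1 to compound 3 (0.17 log units; within the scatter), so the added group leaves the number within the scatter. The same swap at another aromatic carbon gave a 10-fold higher number from compound 1 to compound 2 (1.01 log units; beyond the scatter), so that large rise does not follow from adding a methyl to this ring as such, but differs with the carbon carrying it. As far as these compounds go, how this carbon would respond to a longer chain or an amine stays open. Nothing available explains why the two carbons differ.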